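The source may hold more compounds than are shown below. What is called first, only, known or untested is meant among the compounds shown, and "the series" means these compounds.

Working notes on the series. Compound 1 `Cc1ccc(-c2nnc(-c3sc(-c4cccnc4)nc3C)o2)cc1` in an ADME assay on THP-1 cells (Homo sapiens) for cytotoxicity, read by MTT assay (on this read-out higher numbers stand for lower toxicity in this test and lower numbers for higher toxicity in this test), gives only a limit, > 100 ug/mL. Compound 2 `Cc1nc(-c2cccnc2)sc1-c1nnc(-c2ccc(Cl)cc2)o1` likewise gives a limit, > 100 ug/mL. Compound 3 `Cc1nc(-c2cccnc2)sc1-c1nnc(-c2ccccc2Cl)o1` also gives a limit, > 100 ug/mL. The steps a step that the two limits leave unreadable from compound 1 to compound 2, a step that the two limits leave unreadable from compound 1 to compound 3 and a step that the two limits leave unreadable from compound 2 to compound 3 therefore cannot be sized. Compound 2 stands, with both others, at the limit of > 100 ug/mL in this assay, at which 3 of the 3 values shown sit. Compound 4 `Cc1nc(-c2cccnc2)sc1-c1nnc(-c2ccc([N+](=O)[O-])cc2)o1` differs from compound 2 by nitro in place of chloro on an aromatic carbon. All three measured steps bear on this change only in that none of them could be read, so in this assay the expected step is a step that the limit leaves unreadable from compound 2 to compound 4, none beyond the scatter. Compound 4 is accordingly estimated at 120 ug/mL, from 50 ug/mL to 300 ug/mL, most probably reported again as a limit.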

Compound 4, half-maximal cytotoxic concentration: > 100 ug/mL
Compound 4: only a limit was reported; the forecaster's own chance of this, stated with the estimate: 70%; the middle value lies beyond the limit too.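

For the compounds shown here, no step to compound 4 from compound 1 or compound 2 can be read in this assay: the limit of > 100 ug/mL in this assay, at which 4 of the 4 values shown sit. The compounds shown leave open at what concentration any of them would turn toxic in this test, and whether the aryl substituents differ at all.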